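The source may hold more compounds than are shown below. What is called first, only, known or untested is meant among the compounds shown, and "the series" means these compounds.

Of the compounds shown here, three have been measured in an ADME assay on microsomes from liver (Homo sapiens) for metabolic stability, read by LC-MS, with a stated time of 10 min, tested at 0.5 uM; a higher number here means that more of the compound is left, a lower number that less of the compound is left. Compound 2 (`c1ccc2c(c1)CN[C@@H](CN(CCC1CCNCC1)[C@H]1CCCc3cccnc31)C2`) gives 66%. That value lies within the scatter of compound 3 (`c1cnc2c(c1)CCC[C@@H]2N(CCCN1CCNCC1)Cc1nc2ccccc2[nH]1`), which gives 63%. It lies beyond the scatter from compound 1 (`c1ccc2c(c1)CN[C@H](CN(CCCN1CCNCC1)[C@H]1CCCc3cccnc31)C2`), which gives 99%.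

Compound 4 (`c1ccc2c(c1)CN[C@@H](CN(CCCCN1CCNCC1)[C@H]1CCCc3cccnc31)C2`) differs from compound 2 in one place: 2-(piperazin-1-yl)ethyl in place of piperidin-4-yl on a saturated chain carbon, two bonds along the chain from an amine nitrogen. In words, 2-(piperazin-1-yl)ethyl stands in place of piperidin-4-yl on a saturated chain carbon, two bonds along the chain from an amine nitrogen.

Going by the values given here, no measured step covers this change. Among the compounds with values here, the only step available is a number 36 percentage points lower from compound 1 to compound 3 (beyond the scatter), a large one, and it lies elsewhere in the molecule. It shows that one change can shift this assay strongly, but it gives no direction here. Both compound 1 and compound 3 carry 3-(piperazin-1-yl)propyl, yet compound 1 gives 99% and compound 3 gives 63%, so the presence of piperazin-1-yl alone does not settle the outcome. A step beyond the scatter is therefore not expected, only a slight lean upward. The expected change is a number 6 percentage points higher from compound 2 to compound 4 (within the scatter). The estimate for compound 4 is 72%, with an expected range from 50% to 92%.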

Compound 4, percent of the compound remaining: 82%
Estimate against measurement, compound 4: 10 percentage points below; the range from low to high includes it.
By their numbers in this assay, from the lowest: compounds 3 and 2 (each within the scatter of the next); then compound 4; then compound 1.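

In this assay, going by these compounds alone, putting 2-(piperazin-1-yl)ethyl in place of piperidin-4-yl gives a number 16 percentage points higher from compound 2 to compound 4 (beyond the scatter), the first measured step at this position, on a saturated chain carbon, two bonds along the chain from an amine nitrogen, and it shows that the number can respond to a change made here. Read one bond further out, the change runs from 2-(piperidin-4-yl)ethyl to 4-(piperazin-1-yl)butyl, so the chain and the ring differ together: the six-membered ring gains a second hetero atom, and the group grows from 6 heavy atoms to 8. The data offer no measurement that accounts for this rise.

The compounds shown cannot divide the step between the longer chain and the altered ring, a division that a 4-(piperidin-4-yl)butyl group or a morpholine ring at the end of the same chain could begin to address. They also leave open whether this change would give a similar step with the 1H-benzimidazol-2-yl group of compound 3 in place of the 1,2,3,4-tetrahydroisoquinolin-3-yl group.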